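A few compounds are considered here, and "the series" means these few. Any claim that something is new, unique, unknown or untested is made for them only; others in the source may bear on it.

Compound 1 `Nc1cc(N)c2nc(-c3ccccc3)c(NCc3ccc(Cl)c(Cl)c3)nc2c1` was examined in a functional assay on NCI-H460 cells (Homo sapiens) for inhibition, read by sulforhodamine B assay, with a stated time of 48 h; a lower number here means that less compound is tolerated, a higher number that more compound is tolerated. In this assay compound 1 gives < 100000 nM, which is a limit of the assay and not a number. Compound 2 `CCOC(=O)[C@H](CCC(=O)O)NC(=O)c1ccc(Sc2nc3cc(N)cc(N)c3nc2-c2ccccc2)cc1` was run alongside. In this assay compound 2 gives < 100000 nM, again a limit. The two readings sit together at the limit of < 100000 nM in this assay, at which 2 of the 2 values shown sit, so compound 1 cannot be placed against compound 2 on these numbers. Compound 3 `Nc1cc(N)c2nc(-c3ccccc3)c(NCc3ccc(F)cc3)nc2c1` carries 4-fluorophenyl in place of 3,4-dichlorophenyl on a saturated chain carbon bound to a nitrogen on an aromatic ring. Within the data shown here, with no measured step to guide its size, the step from compound 1 to compound 3 is expected to be a step that the limit leaves unreadable from compound 1 to compound 3, within the scatter. Compound 3 is expected to give 20000 nM in this assay, with a range from 3000 nM to 100000 nM.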

Compound 3, concentration lethal to 50% of the cells: < 100000 nM
Compound 3 was reported as a limit; the forecaster's own chance of this, stated with the estimate: 55%; the middle value is on the limit's open side.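

Compound 3 gives < 100000 nM in this assay, which is again a limit of the assay and not a number. No step can be read between compound 1 and compound 3: the limit of < 100000 nM in this assay, at which 3 of the 3 values shown sit. The compounds shown leave open whether 4-fluorophenyl and 3,4-dichlorophenyl differ at all in this assay.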